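Chain Extension at the Aryl Terminus of Compound 2

The source may report more compounds than this note shows. Statements on the series, on what has been measured and on what is new or still open speak of the compounds shown alone.

Compound 2 `O=C(CCc1ccc(F)cc1)NNc1c(Cl)cncc1Cl` gives 900 nM in a functional assay on HEK293 cells for antagonist activity at P2X purinoceptor 7 (Homo sapiens), read by fluorescence, with a stated time of 2 h; on this read-out higher numbers stand for weaker inhibition and lower numbers for stronger inhibition; its number is the lowest of the three shown, but compound 1 `O=C(CCc1ccccc1)NNc1c(Cl)cccc1Cl` at 1400 nM and compound 3 `COc1ccc(CCC(=O)NNc2c(Cl)cncc2Cl)cc1` at 1500 nM both lie within the scatter of it. Compound 4 `O=C(CCCc1ccccc1)NNc1c(Cl)cncc1Cl` differs from compound 2 by benzyl in place of 4-fluorophenyl on a saturated chain carbon, two bonds along the chain from a carbonyl carbon. Among the measured compounds shown here, the only measured step in one place, a 1.7-fold higher number from compound 2 to compound 3 (0.22 log units; within the scatter), concerns the substituent on the aromatic ring rather than the length of the chain, so it bears only loosely here; compound 1 and compound 2 differ in two places and their values show nothing beyond the scatter. For the measured compounds named here, no measured step addresses the chain itself. For compound 4 the expected step is a 1.3-fold higher number from compound 2 to compound 4 (0.12 log units; within the scatter), none beyond the scatter. The estimate for compound 4 is 1200 nM, within 500 nM to 3000 nM.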

Compound 4, half-maximal inhibitory concentration: 770 nM
Estimate against measurement, compound 4: 1.6-fold (0.19 log units) above; the range from low to high includes it.
By their numbers in this assay, from the lowest: compounds 4, 2, 1 and 3 (each within the scatter of the next).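

In this assay benzyl in place of 4-fluorophenyl on this saturated chain carbon gives a 1.2-fold lower number from compound 2 to compound 4 (0.07 log units; within the scatter) and is the only step shown that alters the chain itself. At this position, the change leaves the two compounds within the scatter of each other, even though it extends the chain and removes the fluorine together. Nothing available gives a reason for this result.

The separate contributions of chain length and fluorine remain unresolved. Also open, going by these compounds, is whether a longer chain, or an amine or carboxylic acid on the terminal ring, would give a step beyond the scatter.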